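Swapping octylcarbonyl for (4-chlorophenyl)carbonyl in compound 3

The source may report more compounds than this note shows. Statements on the series, on what has been measured and on what is new or still open speak of the compounds shown alone.

Measured compounds:
Compound 1, `CC(=O)N1c2ccccc2CCC1C(=O)Nc1cc(C(F)(F)F)cc(C(F)(F)F)c1`: > 70000 nM
Compound 2, `CCCCCCCCC(=O)N1c2ccccc2CCC1C(=O)Nc1ccccc1C(F)(F)F`: 7700 nM

In a functional assay on HCT-15 cells (Homo sapiens) for cytotoxicity, read by sulforhodamine B assay, with a stated time of 72 h (on this read-out higher numbers stand for weaker inhibition of growth and lower numbers for stronger inhibition of growth), compound 1 gives > 70000 nM, which is a limit of the assay and not a number (the limit of > 70000 nM in this assay, at which 1 of the 2 values shown sits). Among the measured compounds shown here, compound 2 gives 7700 nM in this assay, and this is the only real number among the two values shown, so compound 2 stands as the sole measured point of reference, with nothing to rank it against. For the measured compounds named here, no step between two measured compounds is available, since compound 1 and compound 2 differ in more than one place.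

Compound 3, `O=C(Nc1ccccc1C(F)(F)F)C1CCc2ccccc2N1C(=O)c1ccc(Cl)cc1`, differs from compound 2 by 4-chlorophenyl in place of octyl on a carbonyl carbon. Without a measured step of this kind, the change from compound 2 to compound 3 is expected to stay within the usual scatter or to weaken growth inhibition slightly, an expected step of a 1.6-fold higher number from compound 2 to compound 3 (0.19 log units; within the scatter). Compound 3 is therefore estimated at 12000 nM in this assay, with a range from 3000 nM to 45000 nM.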

Compound 3, concentration for 50% growth inhibition: 839 nM
Estimate against measurement, compound 3: 14-fold (1.16 log units) above, and the stated range ends above it.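

In this assay, the group on this carbonyl carbon, whose other neighbour is an amide-type nitrogen in a ring, clearly affects the read-out: 4-chlorophenyl in place of octyl gives a 9.2-fold lower number from compound 2 to compound 3 (0.96 log units; beyond the scatter). Among the compounds shown here, this is the first step that can be read, as compound 1 and compound 2 differ in more than one place, and it shows that an aromatic ring carrying chlorine is tolerated here and goes with stronger inhibition of growth than the octyl chain. Nothing measured here accounts for the size of this step.

The compounds shown leave open whether the gain rests on the ring or on its chlorine, which an unsubstituted phenyl or a 4-methoxyphenyl at this carbonyl carbon would help to separate. They also leave open how a shorter chain such as butyl would read there.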